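The source may report more compounds than this note shows. Statements on the series, on what has been measured and on what is new or still open speak of the compounds shown alone.

Measured compounds:
- Compound 1, `COC(=O)C1=C(C)N=C(C)/C(=C(\O)OC)C1c1ccccc1N`: 39800 nM
- Compound 2, `COC(=O)C1=C(C)N=C(C)/C(=C(\O)OC)C1c1ccc(C#N)cc1`: 3470 nM
- Compound 3, `CCOc1ccccc1C1C(C(=O)OC)=C(C)N=C(C)/C1=C(\O)OC`: 110 nM

In a functional assay (muscle tissue) with Cavia porcellus as the target (on this read-out higher numbers stand for an effect only at larger amounts of compound and lower numbers for an effect already at smaller amounts), compound 1 stands at the top of the three numbers shown; its nearest neighbour is compound 2, with an 11-fold lower number from compound 1 to compound 2 (1.06 log units; beyond the scatter), and the furthest is compound 3, with a 360-fold lower number from compound 1 to compound 3 (2.56 log units; beyond the scatter). Compound 4, `COC(=O)C1=C(C)N=C(C)/C(=C(\O)OC)C1c1ccccc1F`, has not yet been measured in this assay. It differs from compound 1 in one place: fluoro in place of amino on an aromatic carbon. For the measured compounds named here, two measured steps bear on this change. The step from compound 1 to compound 3 swaps the same amino group at the same aromatic carbon for ethoxy and lowers the number by a large margin. The step from compound 1 to compound 2 exchanges the whole 2-aminophenyl for 4-cyanophenyl and also lowers the number, though less. Both steps remove the amino group and both run the same way, so a large step downward in this assay is expected for compound 4, a 130-fold lower number from compound 1 to compound 4 (2.12 log units; beyond the scatter). Compound 4 is therefore estimated at 300 nM, with a range from 50 nM to 2000 nM.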

Compound 4, half-maximal effective concentration: 42.7 nM
Compound 4: middle estimate off by 7.0-fold (0.85 log units), on the high side, outside the stated range (below it).
By their numbers in this assay, from the lowest: compound 4; then compound 3; then compound 2; then compound 1.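

In this assay, fluoro in place of amino gives a 930-fold lower number from compound 1 to compound 4 (2.97 log units; beyond the scatter), the largest step seen so far at this aromatic carbon, and compound 4 now has the lowest number of the four. Ethoxy therefore did not mark the low end for this position: fluoro, with its single heavy atom, goes further, with a 2.6-fold lower number from compound 3 to compound 4 (0.41 log units; beyond the scatter), a modest step but one beyond the scatter. The exchange of 4-cyanophenyl for 2-fluorophenyl gives an 81-fold lower number from compound 2 to compound 4 (1.91 log units; beyond the scatter), but that step changes both the group and its place on the ring, so it cannot be credited to either alone.

Nothing shown explains the size of these steps. As far as these compounds go, it remains open whether chloro, methyl or a nitrile on this same aromatic carbon would give a number close to that of fluoro or of ethoxy, or one as high as that of amino.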